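A few compounds are considered here, and "the series" means these few. Any claim that something is new, unique, unknown or untested is made for them only; others in the source may bear on it.

Measured in a functional assay on SGC-7901 cells (Homo sapiens) for antiproliferative activity, read by MTT assay, with a stated time of 48 h; a lower number here means that less compound is needed, a higher number that more compound is needed for the effect:
- compound 1 `CC1=NN(C(=O)CCl)C(c2cc(Cl)ccc2O)C1`: 14000 nM
- compound 2 `COc1ccc(C(=O)N2N=C(C)CC2c2ccccc2O)cc1`: 45700 nM
- compound 3 `CC1=NN(C(=O)CCl)C(c2cc(Br)ccc2O)C1`: 9210 nM

Compound 3 lies within the scatter of compound 1 and well apart from compound 2, whose number is higher beyond the scatter. Compound 4 `CC1=NN(C(=O)CCl)C(c2cc(F)ccc2O)C1` differs from compound 3 as follows: fluoro in place of bromo on an aromatic carbon, para to a hydroxy group. Among the compounds with values here, one measured step bears on this, also a swap of one halogen at the same place: a 1.5-fold lower number from compound 1 to compound 3 (0.18 log units; within the scatter). Within the data shown here, with only that small step as a guide, no change beyond the scatter is expected in this assay, at most a slight drift to a higher number. The expected step is a 1.6-fold higher number from compound 3 to compound 4 (0.21 log units; within the scatter). Compound 4 is estimated at 15000 nM, with an expected range of 7000 nM to 32000 nM.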

Compound 4, half-maximal effective concentration: 7000 nM
Beside the measured number, compound 4's estimate is 2.1-fold (0.33 log units) above it, within the range that was stated.
By their numbers in this assay, from the lowest: compounds 4, 3 and 1 (each within the scatter of the next); then compound 2.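

At the place para to a hydroxy group, fluoro now joins chloro and bromo: in this assay there is a 1.3-fold lower number from compound 3 to compound 4 (0.12 log units; within the scatter) and a 2.0-fold lower number from compound 1 to compound 4 (0.30 log units; within the scatter). Both steps stay within the scatter, as does the earlier step between chloro and bromo, so the three halogens on the shared core are not told apart at this place. Nothing available explains this result.

Open, going by these compounds, is whether an amine or a carboxylic acid at this place would shift the number beyond the scatter.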